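The source may report more compounds than this note shows. Statements on the series, on what has been measured and on what is new or still open speak of the compounds shown alone.

Measured so far in an assay on isolated protein for inhibition of tyrosine-protein kinase receptor UFO (Homo sapiens), read by LC-MS; on this read-out higher numbers stand for weaker inhibition and lower numbers for stronger inhibition:
compound 1 `COc1ccccc1-c1ccc(-c2nnc(N(C)Cc3ccc4nccn4c3)o2)cc1` gives 1580 nM
compound 2 `Cc1ccccc1-c1ccc(-c2nnc(N(C)Cc3ccc4nccn4c3)o2)cc1` gives 631 nM

Compound 2 holds the lower of the two numbers, the step of a 2.5-fold lower number from compound 1 to compound 2 (0.40 log units; beyond the scatter) being beyond the scatter. Compound 3 `Cc1ncccc1-c1ccc(-c2nnc(N(C)Cc3ccc4nccn4c3)o2)cc1` carries 2-methylpyridin-3-yl in place of 2-methylphenyl on an aromatic carbon. Among the compounds with values here, the only measured step, a 2.5-fold lower number from compound 1 to compound 2 (0.40 log units; beyond the scatter), alters the substituent and not the ring itself, so it does not bear on this change. With no guidance from the series, the expected step of a 1.0-fold lower number from compound 2 to compound 3 (0.00 log units; within the scatter) is none beyond the scatter. Compound 3 is therefore estimated at 630 nM, within a range from 200 nM to 2000 nM.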

Compound 3, half-maximal inhibitory concentration: 6310 nM
Beside the measured number, compound 3's estimate is 10-fold (1.00 log units) below it; measured number outside the range, above it.
By their numbers in this assay, from the lowest: compound 2; then compound 1; then compound 3.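

In this assay the step is a 10-fold higher number from compound 2 to compound 3 (1.00 log units; beyond the scatter) when 2-methylpyridin-3-yl replaces 2-methylphenyl, so changing the ring itself at this position matters more than the earlier substituent change. Against the 2-methoxyphenyl group the same ring gives a 4.0-fold higher number from compound 1 to compound 3 (0.60 log units; beyond the scatter) and places compound 3 highest of the three. Nothing available on these compounds accounts for the rise.

Open, as far as these compounds go, is whether the rise belongs to pyridine rings generally or to this one alone. A pyrimidine ring or a chlorophenyl group at this position would help to separate these readings.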